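Notes on three measured compounds and one expected value

A few compounds are considered here, and "the series" means these few. Any claim that something is new, unique, unknown or untested is made for them only; others in the source may bear on it.

All numbers below come from a functional assay on the whole organism (artery, strain albino) with Rattus norvegicus as the target, with a stated time of 15 min, at a dose of 10 mg/kg by the oral route; a lower number here means less inhibition, a higher number more inhibition at the dose given (going by the name of the read-out).

Compound 1, `CC1=C(C(=O)Nc2ccc(Br)cc2)C(c2ccc(Cl)cc2Cl)N=C(SCc2cccc(Cl)c2)N1`, gives 1.5%.
Compound 2, `CC1=C(C(=O)Nc2ccc(Br)cc2)C(c2ccc(Cl)cc2Cl)N=C(SCc2ccc(Cl)cc2)N1`, gives 4.1%.
Compound 3, `CC1=C(C(=O)Nc2ccc([N+](=O)[O-])cc2)C(c2cccc([N+](=O)[O-])c2)N=C(SCc2cccc(Cl)c2)N1`, gives 2.6%.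

Compound 1 and compound 2 share a core and differ only in 4-chlorophenyl in place of 3-chlorophenyl on a saturated chain carbon bound to a sulfur. That change made a step of a number 2.6 percentage points higher from compound 1 to compound 2 (within the scatter) in this assay. All three measured numbers sit close together: compound 3 lies between compound 1 and compound 2, and none of the pairwise gaps is beyond the scatter, so no order among the three can be read from these data.

Compound 3 carries a core that differs from the core of compound 1 in more than one place; the difference between the two cores is not broken down here.

Compound 4, `CC1=C(C(=O)Nc2ccc([N+](=O)[O-])cc2)C(c2cccc([N+](=O)[O-])c2)N=C(SCc2ccc(Cl)cc2)N1`, is not yet measured. Going by the values given here, it differs from compound 3 by 4-chlorophenyl in place of 3-chlorophenyl on a saturated chain carbon bound to a sulfur, which is the same change as the one from compound 1 to compound 2, made at the same place word for word. Among the compounds with values here, the one earlier instance of this change, a number 2.6 percentage points higher from compound 1 to compound 2 (within the scatter), moved the number only within the scatter. On that basis a step of a number 2.4 percentage points higher from compound 3 to compound 4 (within the scatter) is expected from compound 3 to compound 4, and the expectation is that the number stays small.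

Within the data shown here, for compound 4 the estimate in this assay is 5%, with a range from 0% to 15%, resting on the single earlier step and on the value of compound 3.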

Compound 4, a percentage reported as inhibition, in the whole organism at one dose (the size of the read-out at that dose, not a potency): 2.1%
For compound 4 the middle estimate is 2.9 percentage points above the measured one, and the stated range covers the measured number.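

In this assay, 4-chlorophenyl in place of 3-chlorophenyl on a saturated chain carbon bound to a sulfur gives a step of a number 0.5 percentage points lower from compound 3 to compound 4 (within the scatter) on the nitro-bearing core. Set beside the earlier instance on the core of compound 1, the change shows no difference between the two cores that stands clear of the scatter: the same change on two cores in this assay, a number 2.6 percentage points higher (within the scatter) from compound 1 to compound 2 and a number 0.5 percentage points lower (within the scatter) from compound 3 to compound 4, 3.1 percentage points apart, within the scatter of two such steps

This supports only a narrow statement: on these two cores, at this single dose, the swap of 3-chlorophenyl for 4-chlorophenyl has no readable effect on the number, and the sign of the two steps carries no information. It does not show that the change is without effect on other cores, and with only two instances, both on compounds with small numbers, nothing can be said of how it would behave on a compound with a clearly larger number.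

Whether any group on the sulfur can lift the number clear of the scatter stays open, since an amine, a carboxylic acid or a longer chain in place of the chlorobenzyl group appears in none of the compounds shown. Also open is whether any single one of the several differences between the two cores affects the number, as no pair shown isolates one of them.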